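A few compounds are considered here, and "the series" means these few. Any claim that something is new, unique, unknown or untested is made for them only; others in the source may bear on it.

For the measured compounds named here, compound 2 `Cc1cccc(-c2nc3c(NC4CCCC4)ncnc3n2C)c1` is the only compound with an actual number in a functional assay on CHO cells for antagonist activity at adenosine receptor A2b (Homo sapiens), read by 33P incorporation, with a stated time of 20 min; a higher number here means a weaker inhibitor, a lower number a stronger inhibitor; there compound 2 gives 6030 nM. Compound 1 `Cn1c(-c2ccccc2Cl)nc2c(NC3CCCC3)ncnc21` reaches only a limit of this assay, > 30000 nM. Going by the values given here, the one measured step, an at least 4.9-fold lower number from compound 1 to compound 2 (0.69 log units; beyond the scatter), swaps the whole aryl group and is bounded by the limit of > 30000 nM in this assay, at which 1 of the 2 values shown sits. Among the compounds with values here, compound 3 `Cn1c(-c2ccccc2)nc2c(NC3CCCC3)ncnc21` differs from compound 2 by hydrogen in place of methyl on an aromatic carbon, a smaller change than the measured step, so no measured step speaks directly to it. Compound 3 is expected to sit near compound 2, at an estimated 9000 nM between 3000 nM and 30000 nM, an expected 1.5-fold higher number from compound 2 to compound 3 (0.17 log units; within the scatter).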

Compound 3, inhibition constant: 8510 nM
Compound 3: the middle estimate sits 1.1-fold (0.02 log units) above what was measured, within the range that was stated.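

With hydrogen in place of methyl, this assay shows a 1.4-fold higher number from compound 2 to compound 3 (0.15 log units; within the scatter), so the 3-methylphenyl and the plain phenyl cannot be told apart and this methyl adds nothing visible here. Hydrogen in place of chloro gives an at least 3.5-fold lower number from compound 1 to compound 3 (0.54 log units; beyond the scatter), which ties the earlier difference to the chloro of the 2-chlorophenyl group rather than to the methyl. The size of that step has only a bound: the limit of > 30000 nM in this assay, at which 1 of the 3 values shown sits.

As far as these compounds go, whether the chloro itself or its place on the ring matters stays open. So does the effect of a methoxy, an amine or a carboxylic acid on this phenyl ring.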